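Working notes: from compound 3 to compound 4

The source may report more compounds than this note shows. Statements on the series, on what has been measured and on what is new or still open speak of the compounds shown alone.

Compound 1 `O=C1/C(=C/c2ccc(Cl)cc2)CCC/C1=C\c1ccccc1[N+](=O)[O-]` gives 7600 nM
Compound 2 `CN(C)c1ccc(/C=C2\CCC/C(=C\c3ccccc3[N+](=O)[O-])C2=O)cc1` gives > 400000 nM (a limit of the assay, not a number)
Compound 3 `O=C1/C(=C/c2ccc(F)cc2)CCC/C1=C\c1cccc([N+](=O)[O-])c1` gives 1000 nM
Compound 4 `CN(C)c1ccc(/C=C2\CCC/C(=C\c3cccc([N+](=O)[O-])c3)C2=O)cc1` has not yet been measured

In a functional assay on HL-60 cells (Homo sapiens) for cytotoxicity, with a stated time of 24 h (on this read-out higher numbers stand for lower toxicity in this test and lower numbers for higher toxicity in this test), compound 3 gives 1000 nM, the lowest number in the set and clearly lower than the value for compound 1. The change to compound 4 is dimethylamino in place of fluoro on an aromatic carbon. Within the data shown here, one measured step bears on it: an at least 52-fold higher number from compound 1 to compound 2 (1.72 log units; beyond the scatter), where dimethylamino replaces chloro rather than fluoro. On these data alone, that step is large and ends at the limit of > 400000 nM in this assay, at which 1 of the 3 values shown sits, so its true size remains open. A similar large rise is therefore expected in this assay, towards lower toxicity, and a limit rather than a number is a real possibility. The estimated step is a 120-fold higher number from compound 3 to compound 4 (2.08 log units; beyond the scatter). For compound 4 the expected value is 120000 nM, with an estimated range from 25000 nM to 400000 nM.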

Compound 4, half-maximal cytotoxic concentration: 30000 nM
Compound 4: middle estimate off by 4.0-fold (0.60 log units), on the high side; low and high end bracket the measured number.
By their numbers in this assay, from the lowest: compound 3; then compound 1; then compound 4. At a limit, above all of these: compound 2.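

In this assay, the change from 4-fluorophenyl to 4-(dimethylamino)phenyl now has a full measured size, a 30-fold higher number from compound 3 to compound 4 (1.48 log units; beyond the scatter), and it runs in the same direction as an at least 52-fold higher number from compound 1 to compound 2 (1.72 log units; beyond the scatter), a pair with chloro leaving and 2-nitrophenyl in place of 3-nitrophenyl. The nitrophenyl group also counts while dimethylamino is present, as shown by an at least 13-fold lower number from compound 2 to compound 4 (1.12 log units; beyond the scatter). The true size of that step stays open, since compound 2 gives a limit and not a number: the limit of > 400000 nM in this assay, at which 1 of the 4 values shown sits.

The effect of 3-nitrophenyl in place of 2-nitrophenyl with a halogen on the other aromatic ring cannot be read, as compound 1 and compound 3 differ in two places. On these data alone, whether the rise belongs to dimethylamino alone, or would also follow a primary amine or a methoxy group on the same aromatic carbon, stays open.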